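This account rests on a few compounds, and the source may have more. Where it says the series, first, only, none or still open, it means among the compounds named here.

Three compounds with a shared core, which carries a hydrazide arm, have been measured in an assay on CHO cells for displacement of a labelled ligand from adenosine receptor A1 (Homo sapiens); on this read-out lower numbers stand for stronger inhibition and higher numbers for weaker inhibition. Compound 1 `CCNC(=O)[C@H]1O[C@@H](n2cnc3c(NNC(=O)c4cccnc4)ncnc32)[C@H](O)[C@@H]1O` has a pyridine on the carbonyl of that arm; in this assay compound 1 gives only > 5000 nM, which is a limit of the assay rather than a number (the limit of > 5000 nM in this assay, at which 1 of the 3 values shown sits). Compound 2 `CCNC(=O)[C@H]1O[C@@H](n2cnc3c(NNC(=O)c4ccco4)nc(Cl)nc32)[C@H](O)[C@@H]1O` adds a chlorine to the core and carries a furan-2-yl on the carbonyl carbon; in this assay compound 2 gives 3500 nM. Compound 3 `CCNC(=O)[C@H]1O[C@@H](n2cnc3c(NNC(=O)c4sccc4C)nc(Cl)nc32)[C@H](O)[C@@H]1O` carries a 3-methylthiophen-2-yl instead, and in this assay compound 3 gives 1600 nM, the lowest of the two numbers shown. For the measured compounds named here, the one measured step, a 2.2-fold lower number from compound 2 to compound 3 (0.34 log units; beyond the scatter), exchanges one five-membered aromatic ring for another on the carbonyl carbon.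

Compound 4 `CCNC(=O)[C@H]1O[C@@H](n2cnc3c(NNC(=O)c4cc(-c5ccccc5)on4)nc(Cl)nc32)[C@H](O)[C@@H]1O` makes a larger exchange at the same place: 5-phenyl-1,2-oxazol-3-yl in place of 3-methylthiophen-2-yl on a carbonyl carbon. Only the modest furan-to-thiophene step bears on it, and it does not show how a two-ring group will behave. The number for compound 4 is therefore expected to stay close to compound 3, with a wide spread: an estimated 1.3-fold higher number from compound 3 to compound 4 (0.10 log units; within the scatter), giving compound 4 an expected 2000 nM ranging from 500 nM to 8000 nM.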

Compound 4, inhibition constant: > 5000 nM
Compound 4 was reported as a limit; the forecaster's own chance of this, stated with the estimate: 30%; at least 2.5-fold (0.39 log units) between middle value and limit.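

Compound 4 is reported only as a limit of the assay, not as a number: the limit of > 5000 nM in this assay, at which 2 of the 4 values shown sit.

Even so, in this assay the exchange on the carbonyl carbon gives an at least 3.1-fold higher number from compound 3 to compound 4 (0.49 log units; beyond the scatter), so the lower number seen with 3-methylthiophen-2-yl does not carry over to this two-ring group, and this place does not take every aromatic group equally. The comparison with the furan says less: an at least 1.4-fold higher number from compound 2 to compound 4 (0.15 log units; that floor lies within the scatter), a floor that does not by itself separate those two groups.

This exchange alters the five-membered ring and adds a six-membered ring at once, so the compounds shown cannot say which of the two changes matters. On these data alone, a plain 1,2-oxazol-3-yl without the phenyl, or a saturated ring such as cyclohexyl, on the same carbonyl carbon remains open.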